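This account rests on a few compounds, and the source may have more. Where it says the series, first, only, none or still open, it means among the compounds named here.

Compound 1 `CC(C)C[C@H](N)C(=O)N[C@@H]1CN(c2nc3c(cc2F)c(=O)c(C(=O)O)cn3C2CC2)[C@H]1C`: in a physicochemical assay for solubility, at pH 7.4 (on this read-out higher numbers stand for higher solubility and lower numbers for lower solubility), compound 1 gives > 500 ug/mL, a limit of the assay rather than a number.
Compound 2 `CCC[C@H](N)C(=O)N[C@@H]1CN(c2cc3c(cc2F)c(=O)c(C(=O)O)cn3-c2ccc(F)cc2F)[C@H]1C`: in this assay compound 2 gives > 500 ug/mL, likewise a limit.

Compound 1 therefore stands where every value shown stands, at the limit of > 500 ug/mL in this assay, at which 2 of the 2 values shown sit. Compound 3 `C[C@H](N)C(=O)N[C@@H]1CN(c2nc3c(cc2F)c(=O)c(C(=O)O)cn3C2CC2)[C@H]1C` is the next candidate; it differs from compound 1 by hydrogen in place of isopropyl on a saturated chain carbon, two bonds along the chain from an amine nitrogen and a carbonyl carbon. Among the measured compounds shown here, no step between two measured compounds is available to gauge such a change. The step that the limit leaves unreadable from compound 1 to compound 3 is expected to stay within the scatter, with compound 3 again at or beyond the limit. Compound 3 is estimated at 600 ug/mL, with a range from 300 ug/mL to 1200 ug/mL.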

Compound 3, solubility: > 500 ug/mL
Compound 3 was reported as a limit; the forecaster's own chance of this, stated with the estimate: 85%; the middle value lies beyond the limit too.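

In this assay no step can be read from compound 1 to compound 3, as both values are limits: the limit of > 500 ug/mL in this assay, at which 3 of the 3 values shown sit.

The compounds shown leave open how far each true value lies past that limit, and which structural change, if any, would bring a value within range.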